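A few compounds are considered here, and "the series" means these few. Any claim that something is new, unique, unknown or untested is made for them only; others in the source may bear on it.

Measured compounds:
Compound 1, `CN(C)C(=O)c1cc2cnc(Nc3ccc(S(=O)(=O)NCCCN=C=S)cc3)nc2n1C1CCCC1`, 58.9% in a functional assay on A549 cells (Homo sapiens) for inhibition, read by CCK-8 assay, with a stated time of 72 h, tested at 1 uM; on this read-out higher numbers stand for a stronger effect at the one concentration tested and lower numbers for a weaker effect
Compound 2, `CN(C)C(=O)c1cc2cnc(Nc3ccc(C(=O)NCCCCN=C=S)cc3)nc2n1C1CCCC1`, 30.2% in this assay

Among the compounds with values here, compound 2 stands lowest of the two numbers, and the only measured step, a number 28.7 percentage points lower from compound 1 to compound 2 (beyond the scatter), separates it from compound 1 by more than the scatter. Compound 3, `CN(C)C(=O)c1cc2cnc(Nc3ccc(C(=O)NCCCCCCN=C=S)cc3)nc2n1C1CCCC1`, differs from compound 2 by a group of 5 heavy atoms (3 carbon, 1 nitrogen, 1 sulfur; no ring) in place of a group of 3 heavy atoms (1 carbon, 1 nitrogen, 1 sulfur; no ring), on a saturated chain carbon, four bonds along the chain from an amide-type nitrogen. Within the data shown here, no measured step bears directly on this change: the single step, a number 28.7 percentage points lower from compound 1 to compound 2 (beyond the scatter), exchanged the whole group on the aromatic carbon and says nothing about lengthening the saturated chain that carries the isothiocyanate. With nothing else to go on, no step beyond the scatter is expected in this assay for the move to the longer chain. Compound 3 is therefore estimated at 32% in this assay, with a range of 15% to 50%. This estimate means a step of a number 1.8 percentage points higher from compound 2 to compound 3 (within the scatter) is expected, within the usual scatter.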

Compound 3, a percentage reported as inhibition, at one concentration (the size of the read-out at that concentration, not a potency): 35.8%
Estimate against measurement, compound 3: 3.8 percentage points below; the range from low to high includes it.
By their numbers in this assay, from the lowest: compounds 2 and 3 (each within the scatter of the next); then compound 1.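

Lengthening the saturated chain that carries the isothiocyanate, four bonds along the chain from an amide-type nitrogen, shows a number 5.6 percentage points higher from compound 2 to compound 3 (within the scatter) in this assay and so leaves the number within the scatter. The longer chain does not close the gap on the aromatic carbon, with a number 23.1 percentage points lower from compound 1 to compound 3 (beyond the scatter) still printed as beyond the scatter. Nothing given here accounts for either step.

The group exchanged on the aromatic carbon differs in both its link and its chain, so the compounds shown do not separate the share of each in that gap. Also open, from the compounds shown here alone, is whether a still longer chain, or an amine or a carboxylic acid in place of the isothiocyanate at the chain end, would move the number beyond the scatter.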